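The source may report more compounds than this note shows. Statements on the series, on what has been measured and on what is new or still open speak of the compounds shown alone.

The measured compounds are these two:

Compound 1 `O=c1[nH]cnc2c1c(-c1cccs1)cn2[C@@H]1O[C@H](CO)[C@@H](O)[C@H]1O` gives > 20000 nM in a functional assay on K562 cells (Homo sapiens), read by MTT assay, with a stated time of 72 h (on this read-out lower numbers stand for stronger inhibition and higher numbers for weaker inhibition), a value that is a limit of the assay rather than a number.

Compound 2 `Cc1nc(N)c2c(-c3cccs3)cn([C@@H]3O[C@H](CO)[C@@H](O)[C@H]3O)c2n1` gives > 20000 nM in this assay, again a limit of the assay and not a number.

Compound 1 therefore stands at the edge of what this assay reports, as stated by the limit of > 20000 nM in this assay, at which 2 of the 2 values shown sit. Going by the values given here, both values shown are limits, so no step between measured compounds can be counted, and the two values say only that neither compound reached a measurable inhibition within the concentrations tested.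

The step under study leads from compound 1 to compound 3 `O=c1[nH]cnc2c1c(-c1ccco1)cn2[C@@H]1O[C@H](CO)[C@@H](O)[C@H]1O`. The change is furan-2-yl in place of thiophen-2-yl on an aromatic carbon. Among the compounds with values here, no measured step informs on this change. Given that compound 1 sits at the limit described in the limit of > 20000 nM in this assay, at which 2 of the 2 values shown sit, the step is expected to be none beyond the scatter, and most likely compound 3 will again return only a limit, which is what the expected step that the limit leaves unreadable from compound 1 to compound 3 expresses. For compound 3 in this assay the estimate is 30000 nM, with a range from 10000 nM to 100000 nM.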

Compound 3, half-maximal inhibitory concentration: 15500 nM
Estimate against measurement, compound 3: 1.9-fold (0.29 log units) above; low and high end bracket the measured number.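

In this assay compound 3 gives 15500 nM as a measured number, the first among the compounds shown, so a group at this place on the shared core can yield a reading that is not a limit. Compound 1, which carries thiophen-2-yl at the same place, gives > 20000 nM and this is a limit of the assay and not a number. Going by these compounds alone, the exchange of thiophen-2-yl for furan-2-yl can be stated only as an at least 1.2-fold lower number from compound 1 to compound 3 (0.11 log units; that floor lies within the scatter) and its full size remains unknown, because only one end of the step is a number and the other is bound by a limit: the limit of > 20000 nM in this assay, at which 2 of the 3 values shown sit.

The compounds shown leave open how the read-out responds at this place to a group other than these two five-membered aromatic rings, such as phenyl, an amine or a longer chain. They also leave open whether furan-2-yl would give a measurable number on the core of compound 2, and how far the true potency of compound 1 lies from that of compound 3.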